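Methylsulfanyl replaces methyl in a thiourea series at the limit

This account rests on a few compounds, and the source may have more. Where it says the series, first, only, none or still open, it means among the compounds named here.

Compound 3 `Cc1ccccc1NC(=S)N1CCc2c(sc(NC(=O)c3ccccc3Cl)c2C(N)=O)C1` gives only a limit in a functional assay on HeLa cells (Homo sapiens) for antiproliferative activity, with a stated time of 24 h; on this read-out lower numbers stand for stronger inhibition and higher numbers for weaker inhibition: compound 3 returns > 50000 nM, a limit rather than a number. Compound 1 `Cc1ccccc1CN1CCc2c(sc(NC(=O)c3ccccc3Cl)c2C(N)=O)C1` likewise returns a limit, > 50000 nM. Compound 2 `NC(=O)c1c(NC(=O)c2ccccc2Cl)sc2c1CCN(Cc1ccccc1F)C2` also returns a limit, > 50000 nM. The three steps among them, a step that the two limits leave unreadable from compound 1 to compound 2, a step that the two limits leave unreadable from compound 1 to compound 3 and a step that the two limits leave unreadable from compound 2 to compound 3, have no readable size, since (the limit of > 50000 nM in this assay, at which 3 of the 3 values shown sit).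

Compound 4 `CSc1ccccc1NC(=S)N1CCc2c(sc(NC(=O)c3ccccc3Cl)c2C(N)=O)C1` differs from compound 3 by methylsulfanyl in place of methyl on an aromatic carbon. For the measured compounds named here, no measured step bears on this change, and compound 3 offers only a limit as a starting point, so the expected step that the limit leaves unreadable from compound 3 to compound 4 carries no direction beyond the scatter. Compound 4 is therefore expected at 60000 nM, within 20000 nM to 200000 nM, and most likely again reported only as a limit in this assay.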

Compound 4, half-maximal inhibitory concentration: 43600 nM
Beside the measured number, compound 4's estimate is 1.4-fold (0.14 log units) above it; measured number inside the range.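

Of the compounds shown, only compound 4 gives a number rather than a limit in this assay, at 43600 nM. Methylsulfanyl in place of methyl gives an at least 1.1-fold lower number from compound 3 to compound 4 (0.05 log units; that floor lies within the scatter), while the replacements on the amine nitrogen in the ring give an at least 1.1-fold lower number from compound 2 to compound 4 (0.05 log units; that floor lies within the scatter) and an at least 1.1-fold lower number from compound 1 to compound 4 (0.05 log units; that floor lies within the scatter). These are only floors, and the true sizes stay unread because the other three compounds sit at a limit: the limit of > 50000 nM in this assay, at which 3 of the 4 values shown sit. The compounds shown leave open whether methoxy or ethylsulfanyl on the same aromatic carbon would also give a number in this assay.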